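The source may hold more compounds than are shown below. What is called first, only, known or untested is meant among the compounds shown, and "the series" means these compounds.

Measured so far in a functional assay on the whole organism for inhibition, with Rattus norvegicus as the target, at a dose of 10 mg/kg by the oral route; on this read-out higher numbers stand for a stronger effect at the one dose given and lower numbers for a weaker effect:
compound 1, `Cc1cccnc1C(=O)Nc1nn[nH]n1`, 69%
compound 2, `O=C(Nc1nn[nH]n1)c1ncccc1Cl`, 22%

Compound 2 stands lowest of the two numbers shown; its nearest neighbour is compound 1, and the difference between them, a number 47 percentage points lower from compound 1 to compound 2 (beyond the scatter), is a single change of chloro in place of methyl on an aromatic carbon. Compound 3, `O=C(Nc1nn[nH]n1)c1ccccn1`, has not yet been measured. It differs from compound 2 by hydrogen in place of chloro on an aromatic carbon. Among the measured compounds shown here, no measured step removes a chloro or puts a hydrogen in its place, so the one step that bears on it is only indirect: the large drop from compound 1 to compound 2 shows that this carbon is sensitive to what sits on it. The direction for compound 3 is therefore open. Compound 3 is expected to give about 40% in this assay , with a range from 15% to 70%. This estimate for compound 3 means a step of a number 18 percentage points higher from compound 2 to compound 3 (beyond the scatter), expected but uncertain.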

Compound 3, a percentage reported as inhibition, in the whole organism at one dose (the size of the read-out at that dose, not a potency): 35%
The estimate for compound 3 lay 5 percentage points above the measured number, within the range that was stated.
By their numbers in this assay, from the lowest: compound 2; then compound 3; then compound 1.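

In this assay, the change of hydrogen in place of chloro gives a number 13 percentage points higher from compound 2 to compound 3 (beyond the scatter), and the change of hydrogen in place of methyl gives a number 34 percentage points lower from compound 1 to compound 3 (beyond the scatter). With hydrogen as the reference, this aromatic carbon, two atoms from the ring nitrogen, now reads in both directions: methyl goes with a stronger effect at the one dose given and chloro with a weaker one, so the earlier drop is split into a large step on the methyl side and a modest one on the chloro side. No measurement here accounts for why the two groups part in this way.

As far as these compounds go, whether a longer chain such as ethyl would carry the gain seen with methyl remains open. So does what a methoxy group or an amine on this carbon would give.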